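Methyl for Fluoro on the Ring at the Sulfonyl Sulfur

The compounds below may be only part of what the source reports. "The series", "measured", "known", "first", "only" and "open" are said of these compounds alone.

Compound 1 `O=C(NCc1ccc(CNS(=O)(=O)c2ccccc2F)cc1)c1cccnc1`: 100 nM
Compound 2 `COc1ccccc1C(=O)NCc1ccc(CNS(=O)(=O)c2cccc(F)c2)cc1`: 1000 nM
Compound 3 `COc1ccccc1C(=O)NCc1ccc(CNS(=O)(=O)c2ccc(F)cc2)cc1`: 100 nM

In an assay on MDA-MB-231 cells for displacement of a labelled ligand from C-X-C chemokine receptor type 4 (Homo sapiens), read by fluorescence and microscopy, with stated times of 10 min and 30 min (on this read-out higher numbers stand for an effect only at larger amounts of compound and lower numbers for an effect already at smaller amounts), compound 1 gives 100 nM, level with compound 3 and together with it the lowest of the three numbers, while compound 2 gives 1000 nM. Going by the values given here, the only measured step, a 10-fold lower number from compound 2 to compound 3 (1.00 log units; beyond the scatter), moves a fluoro on the ring at the sulfonyl sulfur and involves neither the leaving nor the entering group of the change now considered. Compound 4 `Cc1ccccc1S(=O)(=O)NCc1ccc(CNC(=O)c2cccnc2)cc1` differs from compound 1 in one place: methyl in place of fluoro on an aromatic carbon. Among the compounds with values here, no measured step bears on this exchange, so compound 1 alone anchors the expectation. For compound 4 the estimated result in this assay is 100 nM, within 30 nM to 300 nM, a step of no change at the digits printed from compound 1 to compound 4 (within the scatter) expected to stay within the scatter.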

Compound 4, effective concentration (reported as EC, without a stated level of effect): 1000 nM
Compound 4: the middle estimate sits 10-fold (1.00 log units) below what was measured; the measured number lies above the stated range.
By their numbers in this assay, from the lowest: compounds 1 and 3 (each within the scatter of the next); then compounds 2 and 4 (each within the scatter of the next).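

Methyl in place of fluoro, on an aromatic carbon ortho to a large group, is the first change shown at this place, and in this assay it gives a 10-fold higher number from compound 1 to compound 4 (1.00 log units; beyond the scatter). The two groups match in what is counted, one heavy atom each and no hydrogen-bond donors or acceptors, yet the step lies beyond the scatter. Nothing available accounts for this step. The compounds shown leave open how a chloro, a methoxy or an amine at this place would read. Also open, as far as these compounds go, is whether the same exchange would give a similar step on the core of compound 3.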